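This account rests on a few compounds, and the source may have more. Where it says the series, first, only, none or still open, it means among the compounds named here.

Compound 2, with the structure `Nc1ccc2cc(NC(=O)CCc3ccc(C(F)(F)F)cc3)ccc2n1`, gives 720 nM in a functional assay on HEK293 cells for activation of melanin-concentrating hormone receptor 1 (Rattus norvegicus), read by inositol phosphate accumulation; a lower number here means that less compound is needed, a higher number that more compound is needed for the effect. Among the measured compounds shown here, that is the highest of the two numbers measured so far; its closest neighbour is compound 1, with the structure `CN(C)c1ccc2cc(NC(=O)CCc3ccc(C(F)(F)F)cc3)ccc2n1`, which gives 110 nM in this assay. For the measured compounds named here, the single step between them, a 6.5-fold higher number from compound 1 to compound 2 (0.82 log units; beyond the scatter), shows that swapping a dimethylamino group for a plain amino group at this spot raises the number noticeably.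

Compound 3, with the structure `O=C(CCc1ccc(C(F)(F)F)cc1)Nc1ccc2nc(N3CCCCCC3)ccc2c1`, has not been measured yet. It differs from compound 2 in one place: azepan-1-yl in place of amino on an aromatic carbon. The new group sits on an aromatic carbon of a six-membered aromatic ring with one nitrogen, next to the ring nitrogen, within a fused system of two rings. Going by the values given here, the only step that bears on this change is the one from compound 1 to compound 2, which goes in the opposite direction, from a group with no hydrogen-bond donors to a free amino group. Compound 3 reverses that, replacing the amino group with a larger ring-shaped amine that again has no hydrogen-bond donor, so a lower number is expected, roughly a 10-fold lower number from compound 2 to compound 3 (1.01 log units; beyond the scatter). For compound 3 the expected value in this assay is 70 nM, within a range from 18 nM to 280 nM.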

Compound 3, half-maximal effective concentration: 1800 nM
Compound 3: middle estimate off by 26-fold (1.41 log units), on the low side; the measured number lies above the stated range.
By their numbers in this assay, from the lowest: compound 1; then compound 2; then compound 3.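

The azepan-1-yl group, with its 0 hydrogen-bond donors, still moves the result in this assay upward, with a 2.5-fold higher number from compound 2 to compound 3 (0.40 log units; beyond the scatter), so the absence of such a donor does not by itself give a low number at this position. The step of a 16-fold higher number from compound 1 to compound 3 (1.21 log units; beyond the scatter) is large, which shows that two groups joined to the aromatic carbon through nitrogen can give clearly different results here, and that what the nitrogen carries matters a great deal. Across these three compounds the numbers do not follow the count of heavy atoms in one direction: amino, with 1 heavy atom, and azepan-1-yl, with 7 heavy atoms, both give higher numbers than dimethylamino.

No measurement shown here explains this order. From the compounds shown here alone, it also remains open whether methylamino, a pyrrolidin-1-yl or piperidin-1-yl ring, or a morpholin-4-yl ring would give a number closer to that of compound 1 or to that of compound 3, and so whether the rise seen with azepan-1-yl sets in gradually or abruptly as the group grows.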